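Extending the alkyl on the core: compound 1 to compound 4

This account rests on a few compounds, and the source may have more. Where it says the series, first, only, none or still open, it means among the compounds named here.

Compound 1, `CCC(CC)Nc1nc(OC)c(-c2ccc(Cl)cc2Cl)nc1C`, 14.4 nM
Compound 2, `CCC(CC)Nc1nc(C)c(-c2ccc(Cl)cc2Cl)nc1C`, 27 nM
Compound 3, `CCc1nc(-c2cnc(C)cc2N(C)C)c(CC)nc1NC(CC)CC`, 7.6 nM

In an assay on IMR-32 cells for displacement of a labelled ligand from corticotropin-releasing factor receptor 1 (Homo sapiens), read by scintillation counting, with a stated time of 2 h (a higher number here means a weaker inhibitor, a lower number a stronger inhibitor), compound 1 gives 14.4 nM. Its nearest neighbour among the measured compounds is compound 2, which differs by a 1.9-fold higher number from compound 1 to compound 2 (0.27 log units; within the scatter), and its furthest is compound 3 with 7.6 nM; both separations lie within the usual scatter, so the three measured compounds cannot be ranked against one another on these numbers.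

Compound 4, `CCc1nc(-c2ccc(Cl)cc2Cl)c(OC)nc1NC(CC)CC`, has not been measured in this assay. It differs from compound 1 by methyl in place of hydrogen on a saturated chain carbon bound to an aromatic carbon, so the change is methyl to ethyl on the shared core. Among the compounds with values here, no measured step shows this change: the only recorded step, from compound 1 to compound 2, exchanges methoxy for methyl on an aromatic carbon and stays within the scatter. Within the data shown here, compound 3 carries ethyl groups on a different core and gives 7.6 nM, but there is no single-point step linking it to compound 1. Among the measured compounds shown here, with no bearing step, no movement beyond the scatter is expected in this assay. Compound 4 is therefore estimated at 12 nM, with a range of 5 nM to 30 nM, which means an expected step of a 1.2-fold lower number from compound 1 to compound 4 (0.08 log units; within the scatter).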

Compound 4, inhibition constant: 8 nM
The estimate for compound 4 lay 1.5-fold (0.18 log units) above the measured number; measured number inside the range.
By their numbers in this assay, from the lowest: compounds 3, 4, 1 and 2 (each within the scatter of the next, the first and the last beyond it).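

The step from methyl to ethyl, methyl in place of hydrogen on a saturated chain carbon bound to an aromatic carbon, gives in this assay a 1.8-fold lower number from compound 1 to compound 4 (0.26 log units; within the scatter). Within the data shown here, this is the first reading at this place on the shared core, since the earlier step, a 1.9-fold higher number from compound 1 to compound 2 (0.27 log units; within the scatter), concerned methoxy and methyl at another place, and it shows that the added carbon leaves the number within the scatter. No other measurement bears on this result, so the numbers offer no explanation for it.

The compounds shown do not tell how far this place can be extended: a longer chain such as propyl or butyl, or a small ring such as cyclopropyl, might stay within the scatter of compound 1 or might move beyond it. They also leave open what a chain ending in an amine or a hydroxyl would do here, and whether the ethyl group would give a similar reading with methyl in place of methoxy on the shared core.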